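The source may report more compounds than this note shows. Statements on the series, on what has been measured and on what is new or still open speak of the compounds shown alone.

Working notes on the series.

Compound 1 `CC(C)=CCC/C(C)=C/CC/C(C)=C/CSc1ccccc1C(=O)N[C@@H](C)C(=O)OCC#CCOc1no[n+]([O-])c1S(=O)(=O)c1ccccc1` gives 7310 nM in a functional assay on U-251 cells (Homo sapiens) for cytotoxicity, read by MTT assay, with a stated time of 48 h; on this read-out higher numbers stand for weaker inhibition and lower numbers for stronger inhibition. Compound 2 `CC(C)=CCC/C(C)=C/CC/C(C)=C/CSc1ccccc1C(=O)N[C@@H](C)C(=O)OC(C)CCOc1no[n+]([O-])c1S(=O)(=O)c1ccccc1` gives 15300 nM in this assay; the difference between the cores of compound 1 and compound 2 is not broken down here, and the two values stand as they are, the gap between them being beyond the scatter. Compound 3 `CC(C)=CCC/C(C)=C/CC/C(C)=C/CSc1ccccc1C(=O)NCC(=O)OC(C)CCOc1no[n+]([O-])c1S(=O)(=O)c1ccccc1` gives 10800 nM in this assay, a value within the scatter of that of compound 1.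

Compound 3 arises from compound 2 by hydrogen in place of methyl on a saturated chain carbon bound to an amide-type nitrogen and a carbonyl carbon, and the measured step is a 1.4-fold lower number from compound 2 to compound 3 (0.15 log units; within the scatter). Compound 4 `CC(C)=CCC/C(C)=C/CC/C(C)=C/CSc1ccccc1C(=O)NCC(=O)OCC#CCOc1no[n+]([O-])c1S(=O)(=O)c1ccccc1` is not yet measured in this assay; it arises from compound 1 by hydrogen in place of methyl on a saturated chain carbon bound to an amide-type nitrogen and a carbonyl carbon. The place of this change is described in the same words in both pairs, so it is taken as the same change, made on the core of compound 1 rather than the core of compound 2. Among the compounds shown it occurs twice, with one measured step.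

Going by the values given here, for compound 1 to compound 4 a step of like size is expected, a 1.3-fold lower number from compound 1 to compound 4 (0.12 log units; within the scatter), resting on the single measured step of a 1.4-fold lower number from compound 2 to compound 3 (0.15 log units; within the scatter), which itself lies within the scatter. Compound 4 is accordingly expected near 5500 nM in this assay. The expected range for compound 4 runs from 2500 nM to 12000 nM, wide enough to hold a repeat of compound 1 as well as a small move in either direction.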

Compound 4, half-maximal inhibitory concentration: 11700 nM
For compound 4 the middle estimate is 2.1-fold (0.33 log units) below the measured one; the measured number falls inside the stated range.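

In this assay, hydrogen in place of methyl on a saturated chain carbon bound to an amide-type nitrogen and a carbonyl carbon gives a 1.6-fold higher number from compound 1 to compound 4 (0.20 log units; within the scatter), so on the core of compound 1, as on the core of compound 2, the step stays within the scatter. The two steps point opposite ways on their face, but the gap between them does not exceed the scatter, so no difference between the two cores can be claimed and the change carries over as a step too small to read: the same change on two cores in this assay, a 1.4-fold lower number (0.15 log units; within the scatter) from compound 2 to compound 3 and a 1.6-fold higher number (0.20 log units; within the scatter) from compound 1 to compound 4, 2.3-fold (0.36 log units) apart, within the scatter of two such steps. Going by these compounds alone, this rests on only two pairs in one cell assay, and it does not show that the change is without effect on any other core, nor does it give the step a reliable direction.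

The compounds shown leave open whether an ethyl group, a benzyl group or a carboxylic acid on the same saturated chain carbon would give a step beyond the scatter. They also leave open whether the replacement of methyl by hydrogen would stay this small on a core other than these two, or when read in a different assay.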